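Chloro for methoxy on an amide-linked diamine series

The compounds below may be only part of what the source reports. "The series", "measured", "known", "first", "only" and "open" are said of these compounds alone.

Four compounds share a free aromatic amine joined through an amide to a linker that ends in a second anilide. Compound 1 `Nc1ccccc1NC(=O)CCCNCC(=O)Nc1ccc(Cl)cc1` and compound 3 `COc1ccc(NC(=O)CNCCCC(=O)Nc2ccccc2N)cc1` carry a flexible chain between the two amide ends, while compound 2 `COc1ccc(NC(=O)CNc2ccc(C(=O)Nc3ccccc3N)cc2)cc1` and compound 4 `Nc1ccccc1NC(=O)c1ccc(NCC(=O)Nc2ccc(Cl)cc2)cc1` hold an aromatic ring in that position. How the core of compound 2 differs from the core of compound 3 is not broken down here.

In a functional assay on the whole organism (Ehrlich cells, Mus musculus) for antiproliferative activity, with a stated time of 24 h, at a dose of 0.2 mmol/kg by the intraperitoneal route (a lower number here means less inhibition, a higher number more inhibition at the dose given (going by the name of the read-out)), compound 1 gives 75%. Compound 3 gives 63.3% in this assay, and compound 2 gives 62.3%. The values of compound 2 and compound 3 lie within the scatter of each other, so nothing is said about their order.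

The change from compound 3 to compound 1 is chloro in place of methoxy on an aromatic carbon, and it brought a step of a number 11.7 percentage points higher from compound 3 to compound 1 (beyond the scatter). Compound 4 arises from compound 2 by the same change, (chloro in place of methoxy on an aromatic carbon), on the other core. Among the compounds with values here, only this one measured pair carries the change, so the expectation rests on it alone; a step of about the same size is expected, a number 10.7 percentage points higher from compound 2 to compound 4 (beyond the scatter), because the step of a number 11.7 percentage points higher from compound 3 to compound 1 (beyond the scatter) is the sole precedent. For compound 4 in this assay the expected value is 73%, with a likely range from 62% to 84%.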

Compound 4, a percentage reported as inhibition, in the whole organism at one dose (the size of the read-out at that dose, not a potency): 73.3%
Estimate against measurement, compound 4: 0.3 percentage points below; the range from low to high includes it.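

In this assay, chloro in place of methoxy on an aromatic carbon brought a number 11 percentage points higher from compound 2 to compound 4 (beyond the scatter), so the change that raised the read-out on the flexible chain core also raised it on the core that holds an aromatic ring. Set side by side, the two steps cannot be told apart in size, and in this series the change carried from one core to the other without visible loss: the same change on two cores in this assay, a number 11.7 percentage points higher (beyond the scatter) from compound 3 to compound 1 and a number 11 percentage points higher (beyond the scatter) from compound 2 to compound 4, 0.7 percentage points apart, within the scatter of two such steps This agreement rests on only two pairs, at a single dose and a single time in one whole-organism read-out, so it gives no potency, does not explain why chloro outdoes methoxy here, and does not show that the step would hold on any further core.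

The compounds shown leave open how a fluoro, a methyl or a plain hydrogen in the same place would compare with chloro and methoxy. They also leave open what a longer chain in the core of compound 1 would do, and whether a hydroxyl in place of the free aromatic amine would keep the inhibition seen with compound 4.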